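Cytotoxicity of benzimidazole analogues: replacing a hydroxy group

The compounds below may be only part of what the source reports. "The series", "measured", "known", "first", "only" and "open" are said of these compounds alone.

Measured compounds:
Compound 1, `Oc1ccc(-c2nc3cc(C(F)(F)F)ccc3[nH]2)cc1`: > 100000 nM
Compound 2, `O=C(CN1CCCC1)Nc1ccc(-c2nc3cc(Cl)c(Cl)cc3[nH]2)cc1`: 64000 nM
Compound 3, `COc1ccc(-c2nc3cc([N+](=O)[O-])ccc3[nH]2)c(OC)c1`: > 100000 nM

Three compounds sharing the same kind of core were tested in an ADME assay on BHK cells (Mesocricetus auratus) for cytotoxicity, read by MTT assay, with a stated time of 96 h; on this read-out lower numbers stand for higher toxicity in this test and higher numbers for lower toxicity in this test. For compound 1 the result is only a limit of the assay, > 100000 nM, not a number. Compound 3 also sits at a limit, > 100000 nM. Only compound 2 gives a number, 64000 nM. So compound 1 stands among the less toxic members of this small set, as far as the limit allows one to say; two of the three values share that position (the limit of > 100000 nM in this assay, at which 2 of the 3 values shown sit).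

The step to compound 4, `O=C(CN1CCCC1)Nc1ccc(-c2nc3cc(C(F)(F)F)ccc3[nH]2)cc1`, changes compound 1 in one place: (((pyrrolidin-1-yl)methyl)carbonyl)amino in place of hydroxy on an aromatic carbon. The new group is the same one that compound 2 carries on its own core.

For the measured compounds named here, no step between measured compounds sets a benchmark here. In this assay a small step toward a lower number, close to the edge of the scatter, is expected, because compound 2 gives 64000 nM in this assay while carrying the same entering group. Compound 4 is therefore expected to show 70000 nM, within a range from 30000 nM to 160000 nM, which means an expected step of an at least 1.4-fold lower number from compound 1 to compound 4 (0.15 log units; that floor lies within the scatter).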

Compound 4, half-maximal cytotoxic concentration: 29000 nM
Beside the measured number, compound 4's estimate is 2.4-fold (0.38 log units) above it, outside the stated range (below it).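

For the compounds shown here, replacing the hydroxy on an aromatic carbon para to a large group with (((pyrrolidin-1-yl)methyl)carbonyl)amino gives an at least 3.4-fold lower number from compound 1 to compound 4 (0.53 log units; beyond the scatter) in this assay, so a change at this position can register clearly in this test, something the earlier compounds could not show with no one-place step among them. Compound 1 gives > 100000 nM as a limit of the assay and not a number. The step therefore marks only the smallest change the data allow, and its full size stays unknown because compound 1 rests on that limit: the limit of > 100000 nM in this assay, at which 2 of the 4 values shown sit.

The entering group brings its pyrrolidine ring, its carbonyl and its amide hydrogen together, so this single step cannot say which of these parts goes with the lower number. Also open, going by these compounds, is whether a plain amino group, an acetylamino group without the ring, or a version with a six-membered piperidine ring in place of the pyrrolidine would move the number in the same direction and by a similar amount.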